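Benzofuranyl for furanyl on two ribosylated cores

The source may hold more compounds than are shown below. What is called first, only, known or untested is meant among the compounds shown, and "the series" means these compounds.

Compound 1 `COc1ncnc2c1c(-c1ccoc1)cn2[C@@H]1O[C@H](CO)[C@@H](O)[C@H]1O` gives 29400 nM in an ADME assay on MRC5 cells (Homo sapiens), read by MTT assay, with a stated time of 72 h; a lower number here means a stronger inhibitor, a higher number a weaker inhibitor. Compound 2 `COc1ncnc2c1c(-c1cc3ccccc3o1)cn2[C@@H]1O[C@H](CO)[C@@H](O)[C@H]1O` gives 65600 nM in this assay. The change between them, (1-benzofuran-2-yl in place of furan-3-yl on an aromatic carbon), produced a 2.2-fold higher number from compound 1 to compound 2 (0.35 log units; beyond the scatter).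

Compound 3 `Nc1nc(N)c2c(-c3ccoc3)cn([C@@H]3O[C@H](CO)[C@@H](O)[C@H]3O)c2n1` carries a different core; the difference between the two cores is not broken down here. In this assay compound 3 reaches only the limit of the assay, > 100000 nM, and not a number, which is the same limit described by the limit of > 100000 nM in this assay, at which 1 of the 3 values shown sits.

Compound 4 `Nc1nc(N)c2c(-c3cc4ccccc4o3)cn([C@@H]3O[C@H](CO)[C@@H](O)[C@H]3O)c2n1` has not yet been measured in this assay. It differs from compound 3 by 1-benzofuran-2-yl in place of furan-3-yl on an aromatic carbon, the same change made from compound 1 to compound 2, at an identically described place. The step from compound 1 to compound 2 was a 2.2-fold higher number from compound 1 to compound 2 (0.35 log units; beyond the scatter), and since compound 3 already sits at a limit, the expected step that the limit leaves unreadable from compound 3 to compound 4 points the same way. Compound 4 is therefore estimated at 220000 nM, within 100000 nM to 500000 nM, most likely again reported only as a limit.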

Compound 4, half-maximal inhibitory concentration: 78500 nM
The estimate for compound 4 lay 2.8-fold (0.45 log units) above the measured number, and the stated range ends above it.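

Placing 1-benzofuran-2-yl in place of furan-3-yl did not carry over unchanged from one core to the other in this assay: the same change on two cores in this assay, a 2.2-fold higher number (0.35 log units; beyond the scatter) from compound 1 to compound 2 and an at least 1.2-fold lower number (0.10 log units; that floor lies within the scatter) from compound 3 to compound 4, at least 2.8-fold (0.45 log units) apart, beyond the scatter of two such steps. Compound 3 is recorded only as a limit of the assay, > 100000 nM, and not as a number. As far as these compounds go, the step on its core is thus only a floor, an at least 1.2-fold lower number from compound 3 to compound 4 (0.10 log units; that floor lies within the scatter), so its true size remains unknown, it does not on its own establish a fall beyond the scatter, and one pair on each core gives no general rule for the series.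

The compounds shown leave open whether other groups on this aromatic carbon, such as a phenyl ring or a thiophene, would also behave differently on the two cores. They also leave open which difference between the cores goes with this divergence, for instance whether a single amine in place of the methoxy group would give the behaviour seen with compound 4.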